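The source may report more compounds than this note shows. Statements on the series, on what has been measured and on what is new or still open speak of the compounds shown alone.

Compound 1, with the structure `COc1ccc(/C=C/c2cc(=O)cco2)cc1`, and compound 2, with the structure `COc1ccc(/C=C/c2cc(=O)cco2)cc1OC`, share one core, while compound 3, with the structure `COc1ccc(/C=C/C2CC=CC(=O)O2)cc1`, carries a different one; how the two cores differ is not broken down here. In a functional assay on U-251 cells (Homo sapiens) for inhibition, read by sulforhodamine B assay, with a stated time of 48 h (on this read-out lower numbers stand for stronger inhibition of growth and higher numbers for weaker inhibition of growth), compound 1 gives 278 uM. In this assay compound 2 gives 339 uM. The change from compound 1 to compound 2 is methoxy in place of hydrogen on an aromatic carbon, and it produced a 1.2-fold higher number from compound 1 to compound 2 (0.09 log units; within the scatter). In this assay compound 3 gives 20.6 uM, the lowest of the three numbers and beyond the scatter from both compound 1 and compound 2.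

Compound 4, with the structure `COc1ccc(/C=C/C2CC=CC(=O)O2)c(OC)c1`, has not been measured in this assay. It differs from compound 3 by methoxy in place of hydrogen on an aromatic carbon. For the measured compounds named here, this is the same kind of change as the one from compound 1 to compound 2, though not the same: in compound 2 the entering methoxy stands ortho to a methoxy group and meta to a group of 9 heavy atoms, whereas in compound 4 it stands ortho to a group of 9 heavy atoms and meta to a methoxy group. Going by the values given here, the step from compound 3 to compound 4 is expected to be a 1.2-fold higher number from compound 3 to compound 4 (0.08 log units; within the scatter), because the only measured instance of this kind of change, a 1.2-fold higher number from compound 1 to compound 2 (0.09 log units; within the scatter), stayed within the scatter. On this basis compound 4 is estimated at 25 uM in this assay. That estimate for compound 4 is expected to lie between 9 uM and 70 uM.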

Compound 4, concentration for growth inhibition (reported as GI): 4.6 uM
Estimate against measurement, compound 4: 5.4-fold (0.74 log units) above; measured number outside the range, below it.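

In this assay, methoxy in place of hydrogen on an aromatic carbon gave a 4.5-fold lower number from compound 3 to compound 4 (0.65 log units; beyond the scatter), so the result seen on the core of compound 1 did not carry over to the core of compound 3: the same change on two cores in this assay, a 1.2-fold higher number (0.09 log units; within the scatter) from compound 1 to compound 2 and a 4.5-fold lower number (0.65 log units; beyond the scatter) from compound 3 to compound 4, 5.5-fold (0.74 log units) apart, beyond the scatter of two such steps

This does not show that the core alone sets the size of the step, as the place of the entering group differs too: in compound 4 the methoxy stands ortho to a group of 9 heavy atoms and meta to a methoxy group, whereas in compound 2 it does not stand there, so core and place cannot be told apart in these two steps. For the compounds shown here, with only one step on each core, no general rule follows, and the pair shows only that a step read on one core cannot safely be taken over to the other.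

The compounds shown leave open whether methoxy at the place it holds in compound 4 would give a similar step on the core of compound 1, and whether methoxy at the place it holds in compound 2 would do so on the core of compound 3. They also leave open how an ethoxy group, a hydroxyl group or a fluorine atom at the place of the entering methoxy would read in this assay.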